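Methoxybenzyl Thioether Tested Against an Allyl Thioether

The compounds below may be only part of what the source reports. "The series", "measured", "known", "first", "only" and "open" are said of these compounds alone.

Compound 2, `C=CCSc1nc2nc(C)cc(N3CC[C@@H](C)[C@@H](N(C)c4ncnc5[nH]ccc45)C3)n2n1`, has been examined in a toxicity assay on GES1 cells (Homo sapiens) for inhibition, read by MTT assay, with a stated time of 72 h; on this read-out higher numbers stand for weaker inhibition and lower numbers for stronger inhibition. In this assay compound 2 gives only a limit, > 100000 nM, so no number is known for it. Two related compounds share its core. Compound 1, `Cc1cc(N2CC[C@@H](C)[C@@H](N(C)c3ncnc4[nH]ccc34)C2)n2nc(SCC3CCCCC3)nc2n1`, carries a cyclohexylmethyl group on the sulfur; in this assay compound 1 gives 98200 nM. Compound 3, `C#CSc1nc2nc(C)cc(N3CC[C@@H](C)[C@@H](N(C)c4ncnc5[nH]ccc45)C3)n2n1`, carries an ethynyl group on the sulfur. In this assay compound 3 gives a limit as well, > 100000 nM. Two steps read an at least 1.0-fold higher number from compound 1 to compound 2 (0.00 log units; that floor lies within the scatter) and an at least 1.0-fold higher number from compound 1 to compound 3 (0.00 log units; that floor lies within the scatter), and the third reads a step that the two limits leave unreadable from compound 2 to compound 3. The frame for all of this is the limit of > 100000 nM in this assay, at which 2 of the 3 values shown sit.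

Compound 4, `COc1ccc(CSc2nc3nc(C)cc(N4CC[C@@H](C)[C@@H](N(C)c5ncnc6[nH]ccc56)C4)n3n2)cc1`, differs from compound 2 by 4-methoxyphenyl in place of vinyl on a saturated chain carbon bound to a sulfur. The measured steps show that exchanging the group on the sulfur among cyclohexylmethyl, allyl and ethynyl leaves the number at or near the limit; none of them involves a 4-methoxybenzyl group, so they guide only loosely. The expectation for compound 4 is nonetheless no step beyond the scatter, expressed as a number no higher from compound 2 to compound 4 (the limit leaves the size open). Compound 4 is estimated at 100000 nM, in a range from 40000 nM to 250000 nM, with a good chance that only a limit is reported again.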

Compound 4, half-maximal inhibitory concentration: > 100000 nM
Compound 4 ended at the assay's limit (the forecaster's own chance of this, stated with the estimate: 60%); the middle value lies on the limit itself.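

The 4-methoxybenzyl group is the first group on the sulfur in this set with a six-membered aromatic ring of carbon only and a hydrogen-bond acceptor, and even this larger group gives no measurable inhibition of the cells in this assay, where compound 4 joins the others at the assay's limit: the limit of > 100000 nM in this assay, at which 3 of the 4 values shown sit.

Among the compounds shown here, the only readable step is an at least 1.0-fold higher number from compound 1 to compound 4 (0.00 log units; that floor lies within the scatter), so it sets a floor and gives no size for the change. The steps from compound 2 and from compound 3 to compound 4 cannot be read, since both ends of each are limits.

Going by these compounds, how far the values of compound 2, compound 3 and compound 4 lie past the limit remains unknown, so these three cannot be ranked against one another. For the compounds shown here, it also remains open whether a carboxylic acid, an amine or a longer chain on the sulfur would bring a clearly lower number than the one compound 1 gives, 98200 nM.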